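The compounds below may be only part of what the source reports. "The series", "measured", "known", "first", "only" and "open" are said of these compounds alone.

Of the compounds shown here, three have so far been measured in a functional assay on HT-29 cells (Homo sapiens) for antiproliferative activity, with a stated time of 4 h; on this read-out lower numbers stand for stronger inhibition and higher numbers for weaker inhibition. Compound 1 `O=C1NC(=O)c2c1c1c(O)cccc1c1[nH]c3ccccc3c21` gives 46400 nM, the highest number of the three and so the weakest inhibition in this small set. Compound 2 `O=c1ccc(=O)c2c1c1[nH]c3ccccc3c1c1c(=O)[nH]c(=O)c21` gives 17400 nM, the nearest value to it, and compound 3 `Cc1ccc2[nH]c3c4c(O)ccc(O)c4c4c(c3c2c1)C(=O)NC4=O` gives 3800 nM, the furthest. Both gaps from compound 1 lie beyond the usual scatter. No two of these compounds differ in one place only, so the measurements supply no direct step to carry over.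

Compound 4 `CC(C)(C)C(=O)Oc1ccc(O)c2c3c(c4c5ccccc5[nH]c4c12)C(=O)NC3=O` departs from compound 1 by ((tert-butyl)carbonyl)oxy in place of hydrogen on an aromatic carbon, para to a hydroxy group. Within the data shown here, with no matching step to draw on, the expectation rests on the spread of the values alone. Compound 1 at 46400 nM sits at the top of that spread, and compound 3 at 3800 nM marks its lower end, so a moderate move toward a lower number is expected, though one beyond the scatter is not assured. The expected size is a 4.2-fold lower number from compound 1 to compound 4 (0.63 log units; beyond the scatter). Compound 4 is estimated at 11000 nM, with an expected range from 3000 nM to 40000 nM.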

Compound 4, half-maximal inhibitory concentration: 7280 nM
Compound 4: the middle estimate sits 1.5-fold (0.18 log units) above what was measured; the range from low to high includes it.
By their numbers in this assay, from the lowest: compounds 3 and 4 (each within the scatter of the next); then compound 2; then compound 1.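

In this assay, among these compounds, the step of a 6.4-fold lower number from compound 1 to compound 4 (0.80 log units; beyond the scatter) is the first comparison in this set that isolates a single place, and it concerns the aromatic carbon para to a hydroxy group. Among the compounds shown here, the result shows that this carbon can carry ((tert-butyl)carbonyl)oxy in place of hydrogen, with its 7 heavy atoms and no ring, without loss of inhibition; the number instead moves modestly toward stronger inhibition, which the earlier compounds, none of them related by a single change, could not show. No measurement at hand bears on why the number falls.

The compounds shown do not tell whether this step belongs to the ((tert-butyl)carbonyl)oxy group itself or would also appear with another group on the same carbon, such as a methoxy group, an acetyloxy group or an amine. For the compounds shown here, they also leave open whether the same replacement would move the number in the same direction on a different parent, since this one step on the core of compound 1 is the only evidence for it.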